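The compounds below may be only part of what the source reports. "The series", "measured", "known", "first", "only" and "open" are said of these compounds alone.

Measured so far in a functional assay on KB cells (Homo sapiens) for cytotoxicity, read by MTT assay, with a stated time of 3 days; a lower number here means a stronger inhibitor, a higher number a weaker inhibitor:

Compound 1, `Cc1cc(C)nc(Oc2ccc(NC(=O)Nc3ccccc3)cc2)n1`, gives only a limit of the assay in this assay, > 50000 nM.
Compound 2, `Cc1cc(C)nc(Oc2ccc(NC(=O)Nc3ccc(OC(F)(F)F)cc3)cc2)n1`, gives 28900 nM in this assay.
Compound 3, `Cc1cc(C)nc(Oc2ccc(NC(=O)Nc3ccc(F)cc3)cc2)n1`, gives 48400 nM in this assay.

Compound 3 thus holds the highest of the two numbers that were actually read, with compound 2 nearest to it: a 1.7-fold higher number from compound 2 to compound 3 (0.22 log units; within the scatter). For compound 1 the assay reported only a limit (the limit of > 50000 nM in this assay, at which 1 of the 3 values shown sits), so no number stands for it.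

Compound 4, `Cc1cc(C)nc(Oc2ccc(NC(=O)Nc3ccc(Cl)cc3Cl)cc2)n1`, is not yet measured. It differs from compound 3 in one place: 2,4-dichlorophenyl in place of 4-fluorophenyl on an amide-type nitrogen. The measured steps that touch the same ring are all small. Adding fluoro to that ring gave an at least 1.0-fold lower number from compound 1 to compound 3 (0.01 log units; that floor lies within the scatter), adding trifluoromethoxy gave an at least 1.7-fold lower number from compound 1 to compound 2 (0.23 log units; that floor lies within the scatter), and exchanging the two gave a 1.7-fold higher number from compound 2 to compound 3 (0.22 log units; within the scatter). None of them is a step beyond the scatter, so changes on this ring have so far left this assay close to unchanged.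

On that basis, compound 4 is expected to stay near compound 3, with an expected step of a 1.4-fold lower number from compound 3 to compound 4 (0.14 log units; within the scatter), which is no step beyond the scatter. The estimate for compound 4 is 35000 nM, with a range from 10000 nM to 100000 nM.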

Compound 4, half-maximal inhibitory concentration: 31800 nM
Compound 4: the middle estimate sits 1.1-fold (0.04 log units) above what was measured; the measured number falls inside the stated range.
By their numbers in this assay, from the lowest: compounds 2, 4 and 3 (each within the scatter of the next). At a limit, above all of these: compound 1.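

Replacing the single fluorine of 4-fluorophenyl with the two chlorines of 2,4-dichlorophenyl, on the same amide-type nitrogen, still leaves the reading in this assay close to unchanged: a 1.5-fold lower number from compound 3 to compound 4 (0.18 log units; within the scatter). Measured against the plain phenyl ring, the same group gives an at least 1.5-fold lower number from compound 1 to compound 4 (0.19 log units; that floor lies within the scatter), and that figure is only a floor, since compound 1 has a limit and not a number: the limit of > 50000 nM in this assay, at which 1 of the 4 values shown sits. So a ring carrying two chlorines now joins the fluoro and trifluoromethoxy rings, and no step on this ring shown so far goes beyond the scatter.

As far as these compounds go, whether an amine or a carboxylic acid on this ring would give a step beyond the scatter remains open. Also open, from the compounds shown here alone, is whether a change in the shared core would move the number further than changes on this ring have.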